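Swapping chloro for methyl on a shared thiazole-thiadiazole core

The compounds below may be only part of what the source reports. "The series", "measured", "known", "first", "only" and "open" are said of these compounds alone.

Compound 1 `CC(=O)c1nn(-c2ccc(Cl)cc2)/c(=N/c2nc(-c3c(C)n(C)n(-c4ccccc4)c3=O)cs2)s1` and compound 3 `CCOC(=O)c1nn(-c2ccc(Cl)cc2)/c(=N/c2nc(-c3c(C)n(C)n(-c4ccccc4)c3=O)cs2)s1` share a core and differ by ethoxy in place of methyl on a carbonyl carbon. In a functional assay on A549 cells (Homo sapiens) for cytotoxicity, read by sulforhodamine B assay, with a stated time of 72 h (on this read-out lower numbers stand for stronger inhibition and higher numbers for weaker inhibition), compound 1 gives only a limit, > 100000 nM. Compound 3 likewise gives only a limit in this assay, > 100000 nM. The step that the two limits leave unreadable from compound 1 to compound 3 therefore cannot be read, since both values sit at the limit of > 100000 nM in this assay, at which 2 of the 3 values shown sit. Compound 2 `CC(=O)c1nn(-c2ccc(C)cc2)/c(=N/c2nc(-c3c(C)n(C)n(-c4ccccc4)c3=O)cs2)s1` arises from compound 1 by methyl in place of chloro on an aromatic carbon, and in this assay compound 2 gives 20700 nM, a step of an at least 4.8-fold lower number from compound 1 to compound 2 (0.68 log units; beyond the scatter). Compound 4 `CCOC(=O)c1nn(-c2ccc(C)cc2)/c(=N/c2nc(-c3c(C)n(C)n(-c4ccccc4)c3=O)cs2)s1` arises from compound 3 by the same change, (methyl in place of chloro on an aromatic carbon). Compound 4 is expected to move by about an at least 2.5-fold lower number from compound 3 to compound 4 (0.39 log units; beyond the scatter), resting on the step of an at least 4.8-fold lower number from compound 1 to compound 2 (0.68 log units; beyond the scatter). Compound 4 is estimated at 40000 nM, between 12000 nM and 150000 nM, though a limit remains possible.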

Compound 4, half-maximal inhibitory concentration: > 100000 nM
Compound 4 ended at the assay's limit (the forecaster's own chance of this, stated with the estimate: 40%); middle value at least 2.5-fold (0.39 log units) from the limit.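

In this assay compound 4 gives > 100000 nM as a limit of the assay and not a number. Compound 3 also sits at a limit, so the change from 4-chlorophenyl to 4-methylphenyl cannot be read on this core, and it may or may not shift the result beyond the assay's range: the limit of > 100000 nM in this assay, at which 3 of the 4 values shown sit.
Going by these compounds alone, the only readable new step, ethoxy in place of methyl on a carbonyl carbon, is an at least 4.8-fold higher number from compound 2 to compound 4 (0.68 log units; beyond the scatter) and shows that the 4-methylphenyl compound with the ethoxy group does not keep a measurable value.

The compounds shown leave open whether another group in that place, such as methoxy or an amine, would bring the ethoxy core into the measurable range. They also leave open how a carboxylic acid would behave in place of the ethoxy group.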